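A few compounds are considered here, and "the series" means these few. Any claim that something is new, unique, unknown or untested is made for them only; others in the source may bear on it.

Measured so far in an assay on isolated protein (strain Sprague-Dawley) for inhibition of Amine oxidase [flavin-containing] B (Rattus norvegicus), read by spectrophotometry, with a stated time of 5 min; a higher number here means a weaker inhibitor, a lower number a stronger inhibitor:

Compound 1, `O=c1cc(O)c2ccc(OCc3cccc(Br)c3)cc2o1`: 490 nM
Compound 2, `COc1cc(=O)oc2cc(OCc3cccc(F)c3)ccc12`: 36.3 nM
Compound 3, `O=c1cc(Oc2ccccc2)c2ccc(OCc3cccc(Cl)c3)cc2o1`: 4070 nM

Among these three, compound 3 has the highest number in this assay, meaning it is the weakest inhibitor of the set; compound 1 is nearest to it and compound 2 furthest from it, both gaps lying beyond the usual scatter of repeated measurements.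

Compound 4, `N#Cc1cc(=O)oc2cc(OCc3cccc(Cl)c3)ccc12`, differs from compound 3 in one place only: cyano in place of phenoxy on an aromatic carbon. The rest of the shared core, including the halogen-bearing benzyloxy group, is kept.

Within the data shown here, no step between two measured compounds matches this change exactly, so the expectation rests on what the other values show. Compound 1 gives 490 nM and compound 2 gives 36.3 nM, and neither carries a phenoxy at that place; compound 3, which does, sits far above both. On that basis the step from compound 3 to compound 4 is expected to be a large drop in the number, well beyond the scatter, estimated as a 68-fold lower number from compound 3 to compound 4 (1.83 log units; beyond the scatter). Compound 4 is therefore expected to reach about 60 nM, within a range of 10 nM to 350 nM.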

Compound 4, half-maximal inhibitory concentration: 102 nM
Beside the measured number, compound 4's estimate is 1.7-fold (0.23 log units) below it; low and high end bracket the measured number.
By their numbers in this assay, from the lowest: compound 2; then compound 4; then compound 1; then compound 3.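

In this assay, this place opposite the ring oxygen proves highly sensitive to its substituent: with the rest of the molecule unchanged, replacing phenoxy with cyano gives a 40-fold lower number from compound 3 to compound 4 (1.60 log units; beyond the scatter). Among these compounds, earlier comparisons could only hint at this, whereas this pair isolates a single change. The swap replaces 7 heavy atoms with 2, removes an aromatic ring and adds a triple bond all at once, while the hydrogen-bond acceptor count stays the same, and nothing shown explains the lower number.

As far as these compounds go, it remains open how an amine, a carboxylic acid or a longer chain would behave at this place. It is also unknown whether the same swap would give a similar step with bromine or fluorine on the benzyloxy group in place of chlorine.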